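Sulfonamide series: aryl swap on the sulfonyl sulfur

This account rests on a few compounds, and the source may have more. Where it says the series, first, only, none or still open, it means among the compounds named here.

For the measured compounds named here, compound 1 `COc1ccc(S(=O)(=O)N2CCC(N3CCC(C)CC3)CC2)cc1OC` is the one member of the set that gives a number: in a functional assay on DLD-1 cells (Homo sapiens) for antiproliferative activity, read by CellTiter-Glo, with a stated time of 72 h (on this read-out lower numbers stand for stronger inhibition and higher numbers for weaker inhibition), compound 1 gives 138 nM. Compound 2 `CC1CCN(C2CCN(S(=O)(=O)c3cccnc3Cl)CC2)CC1` gives only a limit, > 5000 nM in this assay. Compound 3 `Cc1cc(C)c(S(=O)(=O)c2ccc(N3CCC(C)CC3)cc2)c(C)c1`, which carries no sulfonamide nitrogen, likewise gives only a limit, > 5000 nM in this assay. Compound 2 thus stands at the weak end of what has been measured, at the limit of > 5000 nM in this assay, at which 2 of the 3 values shown sit, and no number places it at a known distance from compound 1.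

Compound 4 `CC1CCN(C2CCN(S(=O)(=O)c3ccc(Cl)cc3Cl)CC2)CC1` is not yet measured. It differs from compound 2 in one place: 2,4-dichlorophenyl in place of 2-chloropyridin-3-yl on a sulfonyl sulfur. Compound 1 shows that a carbon-only aromatic ring bearing two substituents on the sulfonyl sulfur can return a measurable number, 138 nM, whereas compound 2 with its ring holding one hetero atom returns none. Going by the values given here, no step between measured compounds sets the size of the change expected here, so the expectation rests on that contrast alone. Compound 4 is expected to move off the limit by a moderate margin, an at least 3.3-fold lower number from compound 2 to compound 4 (0.52 log units; beyond the scatter), without matching compound 1. The estimate for compound 4 in this assay is 1500 nM, with a range from 300 nM to 5000 nM, and a real chance that only a limit is returned again.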

Compound 4, half-maximal inhibitory concentration: 1 nM
Compound 4: middle estimate off by 1500-fold (3.18 log units), on the high side, and the stated range ends above it.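

Exchanging 2-chloropyridin-3-yl for 2,4-dichlorophenyl on a sulfonyl sulfur whose other neighbours are a sulfonamide nitrogen in a ring gives an at least 5000-fold lower number from compound 2 to compound 4 (3.69 log units; beyond the scatter) in this assay, which marks this place as one where a single group exchange can carry the series from a limit to the lowest value shown. The carbon-only rings on this sulfur also do not share one value, with compound 1 at 138 nM and compound 4 at 1 nM, so the printed values show that the substituents on such a ring matter as well as the ring atoms. The step has only a lower bound, because compound 2 gives a limit and not a number: the limit of > 5000 nM in this assay, at which 2 of the 4 values shown sit.

The ring nitrogen leaving and the second chlorine entering change together in this one step, and a phenyl ring bearing one chlorine would be needed to separate them. On these data alone, whether a nitrile or a carboxylic acid on the phenyl ring keeps a value near that of compound 4 in this assay stays open.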